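A Third Phenyl Group on the Sulfonyl Sulfur

The source may hold more compounds than are shown below. What is called first, only, known or untested is meant among the compounds shown, and "the series" means these compounds.

The three compounds here share one core and differ only in the group on the sulfonyl sulfur. In a functional assay on DU-145 cells (Homo sapiens) for antiproliferative activity, read by propidium iodide staining, with a stated time of 96 h (on this read-out higher numbers stand for weaker inhibition and lower numbers for stronger inhibition), compound 1 (`CC(O)(CS(=O)(=O)c1ccc(F)cc1)C(=O)Nc1cccc(S(F)(F)(F)(F)F)c1`) gives 48800 nM and compound 2 (`CC(O)(CS(=O)(=O)c1ccccc1C(F)(F)F)C(=O)Nc1cccc(S(F)(F)(F)(F)F)c1`) gives 27300 nM as its value, so compound 2 stands level with compound 1, the two numbers lying within the scatter of each other. Compound 3 (`CC(O)(CS(=O)(=O)c1ccc(OC(F)(F)F)cc1)C(=O)Nc1cccc(S(F)(F)(F)(F)F)c1`) carries 4-(trifluoromethoxy)phenyl in place of 2-(trifluoromethyl)phenyl on a sulfonyl sulfur. Going by the values given here, the one measured step that bears on this is a 1.8-fold lower number from compound 1 to compound 2 (0.25 log units; within the scatter) at that same sulfur, also a swap of one substituted phenyl for another, so in this assay compound 3 is expected to show no shift beyond the scatter. The estimated step is a 1.1-fold higher number from compound 2 to compound 3 (0.04 log units; within the scatter) and rests on a single comparison. For compound 3 the estimate is 30000 nM (expected range 12000 nM to 70000 nM).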

Compound 3, half-maximal inhibitory concentration: 35600 nM
Beside the measured number, compound 3's estimate is 1.2-fold (0.07 log units) below it; measured number inside the range.
By their numbers in this assay, from the lowest: compounds 2, 3 and 1 (each within the scatter of the next).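

In this assay, 4-(trifluoromethoxy)phenyl in place of 2-(trifluoromethyl)phenyl on the sulfonyl sulfur gives a 1.3-fold higher number from compound 2 to compound 3 (0.12 log units; within the scatter), and trifluoromethoxy in place of fluoro on an aromatic carbon gives a 1.4-fold lower number from compound 1 to compound 3 (0.14 log units; within the scatter). With a third substituted phenyl group, the earlier single comparison becomes a set of three compounds whose steps all lie within the scatter, even though the new group brings in an oxygen atom that the other two groups lack. No measurement is available here to explain this flat result.

All three groups on this sulfur are phenyl rings carrying fluorine. Going by these compounds, it remains open whether a phenyl ring bearing an amine or a carboxylic acid, or a saturated carbon chain in place of the ring, would move the number beyond the scatter.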